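The source may hold more compounds than are shown below. What is called first, only, known or untested is meant among the compounds shown, and "the series" means these compounds.

Measured so far: compound 2 `COc1ccc(C)c(N2CCC(COc3cccc(C(CC(=O)O)C4CC4)c3)CC2)c1` gives 270 nM in a functional assay on cells for agonist activity at Free fatty acid receptor 1 (Homo sapiens), read by FLIPR and calcium flux, with a stated time of 60 min; a lower number here means that less compound is needed, a higher number that more compound is needed for the effect; compound 1 `COc1ccc(F)c(N2CCC(COc3cccc(C(CC(=O)O)C4CC4)c3)CC2)c1` gives 670 nM in this assay.

Compound 2 holds the lower of the two numbers, set apart from compound 1 by a 2.5-fold lower number from compound 1 to compound 2 (0.39 log units; beyond the scatter). Compound 3 `COc1ccc(CN(C)CC(C)C)c(N2CCC(COc3cccc(C(CC(=O)O)C4CC4)c3)CC2)c1` carries isobutyl(methyl)amino in place of hydrogen on a saturated chain carbon bound to an aromatic carbon. Going by the values given here, no measured step covers a change of this kind; the single step on record exchanges one aromatic substituent for another and is only modest. No direction can be read from it, so the expected step of a 1.5-fold higher number from compound 2 to compound 3 (0.17 log units; within the scatter) is uncertain and a wide range is kept. Compound 3 is estimated at 400 nM, range 100 nM to 2000 nM.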

Compound 3, half-maximal effective concentration: 1000 nM
Estimate against measurement, compound 3: 2.5-fold (0.40 log units) below, within the range that was stated.
By their numbers in this assay, from the lowest: compound 2; then compounds 1 and 3 (each within the scatter of the next).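

Placing isobutyl(methyl)amino on a saturated chain carbon bound to an aromatic carbon gives a 3.7-fold higher number from compound 2 to compound 3 (0.57 log units; beyond the scatter) in this assay, so this carbon accepts a large amine-bearing group with a modest loss and activity remains measurable. Against the fluoro group, (isobutyl(methyl)amino)methyl gives a 1.5-fold higher number from compound 1 to compound 3 (0.17 log units; within the scatter), which leaves those two compounds level. Nothing available bears on the origin of these steps.

Open, going by these compounds, is whether the nitrogen or the isobutyl group sets the step. A dimethylamino, morpholine or carboxylic acid group on this carbon could separate those contributions.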